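The source may report more compounds than this note shows. Statements on the series, on what has been measured and on what is new or still open speak of the compounds shown alone.

Series notes. Of the compounds shown here, three have a number so far in an ADME assay on Vero cells (Chlorocebus sabaeus) for cytotoxicity, read by MTT assay, with a stated time of 96 h; on this read-out higher numbers stand for lower toxicity in this test and lower numbers for higher toxicity in this test. Compound 1 `COc1cc(/N=C/c2ccncc2)ccc1-c1cnco1` gives 239000 nM, compound 2 `COc1cc(/N=C/C=C/c2ccccc2)ccc1-c1cnco1` gives 105000 nM, and compound 3 `COc1cc(NCc2ccc(C)s2)ccc1-c1cnco1` gives 24700 nM. Compound 3 stands lowest of the three, beyond the scatter from both compound 2 and compound 1, so it is the most toxic of the measured set in this assay. The next compound, compound 4 `COc1cc(NCc2ccncc2)ccc1-c1cnco1`, differs from compound 3 in one place: pyridin-4-yl in place of 5-methylthiophen-2-yl on a saturated chain carbon bound to a nitrogen on an aromatic ring. The step from compound 3 to compound 4 in this assay is expected to raise the number beyond the scatter, given that compound 1, which also carries pyridin-4-yl, gives 239000 nM. The expected step is a 3.2-fold higher number from compound 3 to compound 4 (0.51 log units; beyond the scatter). Compound 4 is estimated at 80000 nM, with a range of 30000 nM to 240000 nM.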

Compound 4, half-maximal cytotoxic concentration: 342000 nM
For compound 4 the middle estimate is 4.3-fold (0.63 log units) below the measured one; the measured number lies above the stated range.
By their numbers in this assay, from the lowest: compound 3; then compound 2; then compounds 1 and 4 (each within the scatter of the next).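

In this assay, for the compounds shown here, the change to pyridin-4-yl in place of 5-methylthiophen-2-yl on a saturated chain carbon bound to a nitrogen on an aromatic ring gives a 14-fold higher number from compound 3 to compound 4 (1.14 log units; beyond the scatter), the first single-place comparison. The number at this position therefore depends strongly on the group, even though the two groups match in heavy atoms, hydrogen-bond donors and acceptors, and net charge. No evidence on the origin of this step is available.

The compounds shown leave open whether the step follows the ring nitrogen, the ring size or the methyl group. Phenyl or pyridin-3-yl at the same place would bear on this.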